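The source may hold more compounds than are shown below. What is called first, only, known or untested is meant among the compounds shown, and "the series" means these compounds.

Measured compounds:
compound 1 `O=C(CSc1nnc(-c2ccncc2)o1)N/N=C/c1ccc([N+](=O)[O-])cc1`: in a functional assay on MCF7 cells (Homo sapiens) for cytotoxicity, read by MTT assay, with a stated time of 48 h (on this read-out lower numbers stand for stronger inhibition and higher numbers for weaker inhibition), compound 1 gives 31800 nM
compound 2 `Cc1ccc(/C=N/NC(=O)CSc2nnc(-c3ccncc3)o2)cc1`: in this assay compound 2 gives 14700 nM
compound 3 `O=C(CSc1nnc(-c2ccncc2)o1)N/N=C/c1ccccc1[N+](=O)[O-]`: in this assay compound 3 gives 35600 nM

All three share one core and differ only in the aromatic ring attached to the carbon that carries a double bond to nitrogen. Going by the values given here, compound 3 shows the highest of the three numbers, but the step of a 1.1-fold higher number from compound 1 to compound 3 (0.05 log units; within the scatter) stays within the usual scatter, so compound 1 and compound 3 cannot be told apart on this read-out; only the step of a 2.4-fold higher number from compound 2 to compound 3 (0.38 log units; beyond the scatter) is beyond it.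

Compound 4 `COc1cc(/C=N/NC(=O)CSc2nnc(-c3ccncc3)o2)ccc1O` is the next member. Its change from compound 3 is 4-hydroxy-3-methoxyphenyl in place of 2-nitrophenyl on a carbon with a double bond to nitrogen. Among the compounds with values here, no measured compound carries this hydroxy-methoxy pattern, so the closest guidance comes from steps in which a nitro group is exchanged for something else: a 2.2-fold lower number from compound 1 to compound 2 (0.34 log units; beyond the scatter) and, read in reverse, a 2.4-fold higher number from compound 2 to compound 3 (0.38 log units; beyond the scatter). Both are modest and both point to a lower number when the nitro group is removed. A step of similar modest size downward is therefore expected, a 1.8-fold lower number from compound 3 to compound 4 (0.25 log units; within the scatter), with added uncertainty since the entering group is new. Compound 4 is estimated to give 20000 nM in this assay, within a range of 8000 nM to 50000 nM.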

Compound 4, half-maximal inhibitory concentration: 3780 nM
Estimate against measurement, compound 4: 5.3-fold (0.72 log units) above; the whole stated range lies above it.
By their numbers in this assay, from the lowest: compound 4; then compound 2; then compounds 1 and 3 (each within the scatter of the next).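

Going by these compounds alone, exchanging the earlier rings for 4-hydroxy-3-methoxyphenyl on the carbon with a double bond to nitrogen shifts the result in this assay further than the exchanges among the nitrophenyl and methylphenyl rings did, with a 9.4-fold lower number from compound 3 to compound 4 (0.97 log units; beyond the scatter) and an 8.4-fold lower number from compound 1 to compound 4 (0.92 log units; beyond the scatter) as the two largest steps, while a 3.9-fold lower number from compound 2 to compound 4 (0.59 log units; beyond the scatter) shows that the new ring also improves on the best of the earlier compounds. Within the data shown here, all three steps lie beyond the scatter, so compound 4 is the most potent of the four on this read-out, and this position can change the cell result more than the earlier compounds alone revealed. Nothing available here offers a reason for the drop in the number.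

The entering ring carries a hydroxy group and a methoxy group together, so the compounds shown cannot reveal whether one of them alone would account for the step or whether both are needed. On these data alone, it also remains open how this position would respond to a ring bearing an amine or a carboxylic acid, or to a ring with two methoxy groups.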